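The source may hold more compounds than are shown below. What is called first, only, known or untested is meant among the compounds shown, and "the series" means these compounds.

Series notes. In a functional assay (a higher number here means a weaker inhibitor, a lower number a stronger inhibitor), compound 1 `C=CC(C)(C)c1[nH]c2ccc(C[C@H]3OC(C)(C)OC3(C)C)cc2c1/C=C1\NC(=O)[C@H](C)NC1=O` gives 88000 nM, and compound 2 `C=CC(C)(C)c1[nH]c2ccc(CC=C(C)C)c(CC=C(C)C)c2c1C[C@@H]1NC(=O)[C@H](C)NC1=O` gives 623000 nM, the higher of the two numbers here and beyond the scatter from compound 1. Compound 3 `C=CC(C)(C)c1[nH]c2ccc(CC=C(C)C)c(CC=C(C)C)c2c1/C=c1\[nH]c(=O)c(=C)[nH]c1=O` is the next case, as yet unmeasured. The change from compound 2 to compound 3 is a group of 10 heavy atoms (6 carbon, 2 nitrogen, 2 oxygen; one six-membered aromatic ring with 2 hetero atoms) in place of a group of 10 heavy atoms (6 carbon, 2 nitrogen, 2 oxygen; one six-membered non-aromatic ring with 2 hetero atoms), on an aromatic carbon. Within the data shown here, no step between measured compounds involves this change, and only two measured numbers exist, so the expectation is loose: a modest downward step beyond the scatter from compound 2, estimated as a 4.2-fold lower number from compound 2 to compound 3 (0.62 log units; beyond the scatter). Compound 3 is expected to give 150000 nM in this assay, within 30000 nM to 700000 nM.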

Compound 3, half-maximal inhibitory concentration: 51000 nM
Beside the measured number, compound 3's estimate is 2.9-fold (0.47 log units) above it, within the range that was stated.
By their numbers in this assay, from the lowest: compounds 3 and 1 (each within the scatter of the next); then compound 2.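

In this assay, among these compounds, the group on this aromatic carbon of the five-membered ring is exchanged with a 12-fold lower number from compound 2 to compound 3 (1.09 log units; beyond the scatter), the only single-place step and a large one. The (5-methyl-3,6-dioxopiperazin-2-yl)methyl group gives way to a six-membered aromatic ring group, so activity here responds to the form of this group even with heavy-atom and hydrogen-bond donor and acceptor counts unchanged. No measurement at hand accounts for the step. Going by these compounds, whether the aromatic ring or the added outer double bonds carry the step stays open, as does how an amine or a carboxylic acid on this ring would read.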